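The compounds below may be only part of what the source reports. "The series", "measured", "known", "first", "only" and "open" are said of these compounds alone.

Measured so far:
compound 1 `CC(=O)Nc1nc(-c2cccc(NS(=O)(=O)c3ccc(C#CC4CCCCC4)cc3)c2)cs1` gives 1.2%
compound 2 `CCCCCCC#Cc1cccc(S(=O)(=O)Nc2cccc(-c3csc(NC(C)=O)n3)c2)c1` gives 1.2%

In a functional assay on A-375 cells (Homo sapiens) for antiproliferative activity, read by trypan blue exclusion, with a stated time of 48 h, tested at 5 uM (on this read-out lower numbers stand for a stronger effect and higher numbers for a weaker effect at the one concentration tested), compound 1 stands level with compound 2 at the digits shown; the two values lie within the usual scatter, so nothing separates them. For the measured compounds named here, no step between measured compounds is available for the change at hand.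

Compound 3 `CCCCCCCCc1ccc(S(=O)(=O)Nc2cccc(-c3csc(NC(C)=O)n3)c2)cc1` differs from compound 1 by octyl in place of 2-cyclohexylethynyl on an aromatic carbon: octyl in place of 2-cyclohexylethynyl, on an aromatic carbon para to a large group, the triple bond and the six-membered non-aromatic ring leaving while the count of heavy atoms stays equal. Since compound 1 and compound 2, which carry different substituents at a similar position, both give a value near the floor of the read-out in this assay, the step from compound 1 to compound 3 is expected to be small, at most a slight weakening, and likely within the scatter; the expected step is a number 2.8 percentage points higher from compound 1 to compound 3 (within the scatter). Compound 3 is therefore estimated at 4%, with a range from 0% to 20%.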

Compound 3, a percentage reported as activity, at one concentration (the size of the read-out at that concentration, not a potency): < 1%
Compound 3 gave a limit, no number; the forecaster's own chance of this, stated with the estimate: 5%; middle value at least 3 percentage points from the limit.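

Compound 3 gives < 1% in this assay, and this is a limit of the assay, not a number. The step reads a number at least 0.2 percentage points lower from compound 1 to compound 3 (that floor lies within the scatter), so on an aromatic carbon para to a large group, octyl can stand in place of 2-cyclohexylethynyl with no change beyond the scatter, which shows that neither the triple bond nor the six-membered non-aromatic ring is needed to keep the read-out this low at the one concentration tested. Any difference between the two compounds remains hidden at the end of the scale: the limit of < 1% in this assay, at which 1 of the 3 values shown sits.

On these data alone, it remains open whether a much shorter chain, an amine or a carboxylic acid on this carbon would keep the read-out this low. A single concentration this close to the limit also leaves the relative potency of compound 1 and compound 3 unknown.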